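The compounds below may be only part of what the source reports. "The series", "measured", "known", "first", "only" and "open" are said of these compounds alone.

Of the compounds shown here, three have been measured in an assay on isolated protein with Bile acid receptor (Homo sapiens) as the target (a higher number here means that more compound is needed for the effect, a lower number that less compound is needed), so far. Compound 3 `COC(=O)/C=C/c1cccc(N(Cc2ccc(-c3cc(Cl)ccc3OC)cc2)C(=O)C(C)C)c1` gives 226 nM in this assay, and the other two lie close to it: compound 1 `COC(=O)/C=C/c1cccc(N(Cc2ccc(/C=C/c3cccc(C(F)(F)F)c3)cc2)C(=O)C(C)C)c1` gives 267 nM and compound 2 `COC(=O)/C=C/c1cccc(N(Cc2ccc(/C=C/c3ccccn3)cc2)C(=O)C(C)C)c1` gives 310 nM. The step of a 1.2-fold lower number from compound 1 to compound 3 (0.07 log units; within the scatter) and the step of a 1.4-fold lower number from compound 2 to compound 3 (0.14 log units; within the scatter) both fall within the scatter, as does a 1.2-fold higher number from compound 1 to compound 2 (0.06 log units; within the scatter), so compound 3 stands together with compounds 1 and 2 rather than apart from them.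

Compound 4 `COC(=O)/C=C/c1cccc(N(Cc2ccc(-c3cccc(OC(F)(F)F)c3)cc2)C(=O)C(C)C)c1` changes the same position of the shared core: 3-(trifluoromethoxy)phenyl in place of 5-chloro-2-methoxyphenyl on an aromatic carbon. Within the data shown here, the steps that bear on this are the two already seen at that aromatic carbon, from compound 1 and from compound 2 to compound 3, and both were within the scatter. Three different groups at this position therefore gave values that cannot be told apart, and the trifluoromethoxyphenyl group is expected to behave likewise, with a step of a 1.1-fold higher number from compound 3 to compound 4 (0.04 log units; within the scatter) in this assay. Compound 4 is thus estimated at 250 nM, in a range from 110 nM to 560 nM.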

Compound 4, half-maximal effective concentration: 247 nM
For compound 4 the middle estimate is 1.0-fold (0.01 log units) above the measured one; measured number inside the range.
By their numbers in this assay, from the lowest: compounds 3, 4, 1 and 2 (each within the scatter of the next).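

In this assay, replacing 5-chloro-2-methoxyphenyl with 3-(trifluoromethoxy)phenyl gives a 1.1-fold higher number from compound 3 to compound 4 (0.04 log units; within the scatter), so this position accepts a change from chlorine to fluorine and from 9 to 11 heavy atoms without a shift that can be told from the scatter. The comparisons with the two ethenyl-containing groups agree, with a 1.3-fold lower number from compound 2 to compound 4 (0.10 log units; within the scatter) and a 1.1-fold lower number from compound 1 to compound 4 (0.03 log units; within the scatter), so all four groups tested on this aromatic carbon give values that cannot be separated. No evidence is available to explain why the values stay so close.

Going by these compounds, all four groups contain a six-membered aromatic ring, so it remains open whether the values would hold with an amine, a carboxylic acid or a simple methyl group at this carbon. On these data alone, the effect of replacing the methyl ester elsewhere on the shared core also remains open.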